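This account rests on a few compounds, and the source may have more. Where it says the series, first, only, none or still open, it means among the compounds named here.

Working notes on the series, values in a physicochemical assay for solubility, at pH 7.4; a higher number here means a more soluble compound, a lower number a less soluble compound:

- compound 1 `CSc1ccc(NC(=O)Nc2cc(C)nc3ccccc23)cc1`: 1300 nM
- compound 2 `COC(=O)c1ccc(NC(=O)Nc2cc(C)nc3ccccc23)cc1`: 1200 nM
- compound 3 `Cc1cc(NC(=O)Nc2ccc(C(N)=O)cc2)c2ccccc2n1`: 900 nM

Compound 3, at 900 nM, stands within the scatter of both other compounds, so the three values give no order. The next compound is compound 4 `Cc1cc(NC(=O)Nc2ccc(N)cc2)c2ccccc2n1`, not yet measured. It has one change from compound 3: amino in place of carbamoyl on an aromatic carbon. In words, this is amino in place of carbamoyl on an aromatic carbon, para to a large group.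

For the measured compounds named here, three measured steps concern the group at that place: a 1.1-fold lower number from compound 1 to compound 2 (0.03 log units; within the scatter), a 1.4-fold lower number from compound 1 to compound 3 (0.16 log units; within the scatter) and a 1.3-fold lower number from compound 2 to compound 3 (0.12 log units; within the scatter). All three stay within the scatter, across methylsulfanyl, methoxycarbonyl and carbamoyl. Going by the values given here, none of the measured compounds carries amino there, so the evidence is indirect. No step beyond the scatter is expected in this assay, and the direction is only weakly held. The expected step is a 1.3-fold higher number from compound 3 to compound 4 (0.12 log units; within the scatter), which remains an estimate. Going by these compounds, the range is kept wider than the measured spread, since amino is untested. For compound 4 the estimated value is 1200 nM, with an expected range from 500 nM to 3500 nM.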

Compound 4, solubility: 18500 nM
Compound 4: the middle estimate sits 15-fold (1.19 log units) below what was measured; the measured number lies above the stated range.
By their numbers in this assay, from the lowest: compounds 3, 2 and 1 (each within the scatter of the next); then compound 4.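

In this assay, this place on the aromatic carbon, para to a large group, is not indifferent to its substituent, as the steps among methylsulfanyl, methoxycarbonyl and carbamoyl, all within the scatter, had made it appear. Amino separates from all three groups: in place of carbamoyl it gives a 21-fold higher number from compound 3 to compound 4 (1.31 log units; beyond the scatter), in place of methoxycarbonyl it gives a 15-fold higher number from compound 2 to compound 4 (1.19 log units; beyond the scatter), and in place of methylsulfanyl it gives a 14-fold higher number from compound 1 to compound 4 (1.15 log units; beyond the scatter), so compound 4 stands beyond the scatter of every other compound in the series, and the size of the step holds whichever of the three groups is replaced. Nothing at hand accounts for this step.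

The compounds shown leave open whether the step belongs to amino alone or extends to a methylamino, dimethylamino, aminomethyl or acetamido group at the same place. They also leave open how a carboxylic acid there would compare, and whether amino placed elsewhere on this ring would give a step of similar size.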